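The source may report more compounds than this note shows. Statements on the series, on what has been measured and on what is new or still open speak of the compounds shown alone.

Compound 1 `COc1ccc(S(C)(=O)=O)c(NCC2=NCCN2)c1`: in a functional assay for agonist activity at Alpha-1D adrenergic receptor (Homo sapiens) (a higher number here means that more compound is needed for the effect, a lower number that less compound is needed), compound 1 gives < 100000 nM, which is a limit of the assay rather than a number. Compound 2 `CS(=O)(=O)c1ccc(F)cc1NCC1=NCCN1`: compound 2 gives < 100000 nM, likewise a limit. Compound 3 `Cc1ccc(S(C)(=O)=O)c(NCC2=NCCN2)c1`: compound 3 gives < 2000 nM, again a limit.

Compound 1 therefore stands at the limit of < 100000 nM in this assay, at which 2 of the 3 values shown sit, while compound 3 sits at the limit of < 2000 nM in this assay, at which 1 of the 3 values shown sits. For the measured compounds named here, the three steps among the measured compounds, a step that the two limits leave unreadable from compound 1 to compound 2, a step that the two limits leave unreadable from compound 1 to compound 3 and a step that the two limits leave unreadable from compound 2 to compound 3, cannot be read in size, and each of them alters a different group from the one changed in compound 4 `COc1ccc(SC)c(NCC2=NCCN2)c1`, where (methylsulfanyl in place of methylsulfonyl on an aromatic carbon). Going by the values given here, no measured step bears on this change, and the expected step that the limit leaves unreadable from compound 1 to compound 4 is set near no change beyond the scatter, with a wide range. Compound 4 is expected to give 30000 nM, somewhere between 3000 nM and 100000 nM.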

Compound 4, half-maximal effective concentration: 5.01 nM
Compound 4: middle estimate off by 6000-fold (3.78 log units), on the high side; the whole stated range lies above it.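

Compound 1 is known only through a limit of the assay, and the step from it to compound 4 cannot be read in size. The compounds shown leave open how large the step for methylsulfanyl in place of methylsulfonyl is.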